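Replacing ethyl with carbamoyl on the shared core

The compounds below may be only part of what the source reports. "The series", "measured", "known", "first", "only" and "open" are said of these compounds alone.

Of the compounds shown here, three sharing one core have been measured in an ADME assay on HEp-2 cells (Homo sapiens) for cytotoxicity; on this read-out higher numbers stand for lower toxicity in this test and lower numbers for higher toxicity in this test. Compound 1 `CC(C)CCn1c(Cn2c(=O)n(C(C)C)c3ccccc32)nc2cc(CN(C)C)ccc21` gives 5650 nM, compound 2 `CC(C)CCn1c(Cn2c(=O)n(C(C)C)c3ccccc32)nc2cc(CF)ccc21` gives 37300 nM, and compound 3 `CCc1ccc2c(c1)nc(Cn1c(=O)n(C(C)C)c3ccccc31)n2CCC(C)C` gives 18500 nM. Compound 3 holds the second highest of these numbers, with a 2.0-fold lower number from compound 2 to compound 3 (0.30 log units; within the scatter) on one side and a 3.3-fold higher number from compound 1 to compound 3 (0.52 log units; beyond the scatter) on the other.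

Compound 4 `CC(C)CCn1c(Cn2c(=O)n(C(C)C)c3ccccc32)nc2cc(C(N)=O)ccc21` has not been measured. It has carbamoyl in place of ethyl on an aromatic carbon. Among the measured compounds shown here, no measured compound carries carbamoyl, so the evidence is indirect. The measured steps concern groups on a saturated chain carbon bound to an aromatic carbon. Beyond the scatter, they involve only the loss of dimethylamino, as in a 6.6-fold higher number from compound 1 to compound 2 (0.82 log units; beyond the scatter). Compound 4 has no dimethylamino group, so the expectation stays anchored on compound 3 at 18500 nM. The expected change is small, a 1.2-fold higher number from compound 3 to compound 4 (0.08 log units; within the scatter), with no shift beyond the scatter. For compound 4 the estimated value in this assay is 22000 nM, within an expected range of 8000 nM to 50000 nM.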

Compound 4, half-maximal cytotoxic concentration: 23400 nM
Beside the measured number, compound 4's estimate is 1.1-fold (0.03 log units) below it, and the stated range covers the measured number.
By their numbers in this assay, from the lowest: compound 1; then compounds 3, 4 and 2 (each within the scatter of the next).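

On this aromatic carbon of the shared core, carbamoyl brings a hydrogen-bond donor and a hydrogen-bond acceptor that ethyl lacks, yet in this assay the swap stays within the scatter (a 1.3-fold higher number from compound 3 to compound 4 (0.10 log units; within the scatter)), as does carbamoyl in place of fluoromethyl (a 1.6-fold lower number from compound 2 to compound 4 (0.20 log units; within the scatter)). Only carbamoyl in place of (dimethylamino)methyl gives a step beyond the scatter (a 4.1-fold higher number from compound 1 to compound 4 (0.62 log units; beyond the scatter)), so this new group joins ethyl and fluoromethyl, leaving compound 1 alone at the low end. No measurement shown gives a reason for these numbers.

Still open, on these data alone, is whether an amine or a carboxylic acid on this aromatic carbon would give a number like that of compound 1 or like that of compound 4. A longer chain ending in dimethylamino is equally untested among these compounds.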